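Meta-substituted anilines on the benzofuran amidoxime series

The source may report more compounds than this note shows. Statements on the series, on what has been measured and on what is new or still open speak of the compounds shown alone.

Measured compounds in an assay on tissue (HeLa cells) for inhibition of Indoleamine 2,3-dioxygenase 1 (Homo sapiens), read by spectrophotometry; a higher number here means a weaker inhibitor, a lower number a stronger inhibitor:
- compound 1 `O/N=C(/Nc1ccc(Cl)cc1)c1ccc2occc2c1`: > 30000 nM.
- compound 2 `O/N=C(/Nc1cccc(C(F)(F)F)c1)c1ccc2occc2c1`: 1900 nM.
- compound 3 `O/N=C(/Nc1ccc(F)c(C(F)(F)F)c1)c1ccc2occc2c1`: 2200 nM.

The result of compound 1 is a limit of the assay, not a number. One of the three values sits at that limit (the limit of > 30000 nM in this assay, at which 1 of the 3 values shown sits). Compound 2 holds the lowest of the two numbers actually read, and compound 3 is its nearest neighbour; the step from compound 2 to compound 3 is a 1.2-fold higher number from compound 2 to compound 3 (0.06 log units; within the scatter), so the two are indistinguishable here.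

The next compound, compound 4 `O/N=C(/Nc1cccc(-c2ccccc2)c1)c1ccc2occc2c1`, differs from compound 2 by phenyl in place of trifluoromethyl on an aromatic carbon. Going by the values given here, no measured step in this set bears directly on it: the only step in hand, fluoro in place of hydrogen from compound 2 to compound 3, was within the scatter and concerns a different position and a much smaller group. Among the compounds with values here, the two numbers read so far show that a group at this position on the aniline is tolerated, but nothing tells how a six-membered aromatic ring there would behave. The expectation is therefore a step close to none beyond the scatter, with wide uncertainty: a 1.6-fold higher number from compound 2 to compound 4 (0.20 log units; within the scatter). Compound 4 is estimated at 3000 nM, with a range from 800 nM to 15000 nM.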

Compound 4, half-maximal inhibitory concentration: 11900 nM
For compound 4 the middle estimate is 4.0-fold (0.60 log units) below the measured one; measured number inside the range.
By their numbers in this assay, from the lowest: compounds 2 and 3 (each within the scatter of the next); then compound 4. At a limit, above all of these: compound 1.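

Phenyl in place of trifluoromethyl is the first change in this set to give a step beyond the scatter, which shows that this position, meta to a large group, is not indifferent to the group it carries (a 6.3-fold higher number from compound 2 to compound 4 (0.80 log units; beyond the scatter)), as read in this assay. Compound 4 still returns a read number, so a six-membered aromatic ring of carbon only is accepted at this position, though at a modest cost against trifluoromethyl in compound 2. No measurement at hand bears on why the step occurs.

As far as these compounds go, a single step cannot separate the presence of a ring from the other differences between the two groups, so it remains open whether a methyl, a methoxy or a saturated cyclohexyl ring at this position would give a number nearer that of compound 2 or that of compound 4. Also open, from the compounds shown here alone, is whether a phenyl ring carrying an amine or a carboxylic acid would move the number in either direction from that of compound 4.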